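A few compounds are considered here, and "the series" means these few. Any claim that something is new, unique, unknown or untested is made for them only; others in the source may bear on it.

For compound 1 `COc1cccc(/C=C2\CCC/C(=C\c3ccc(O)cc3)C2=O)c1OC` the result in a functional assay on MCF7 cells (Homo sapiens) for cytotoxicity, read by MTT assay, with a stated time of 72 h (on this read-out lower numbers stand for stronger inhibition and higher numbers for weaker inhibition), is a limit rather than a number: > 20000 nM, which is the limit of > 20000 nM in this assay, at which 1 of the 3 values shown sits. Compound 2 `COc1cc(/C=C2\CCC/C(=C\c3cccc(OC)c3OC)C2=O)ccc1O` gives 11600 nM in this assay; here methoxy in place of hydrogen on an aromatic carbon brings an at least 1.7-fold lower number from compound 1 to compound 2 (0.23 log units; that floor lies within the scatter). Compound 3 `COc1ccc(/C=C2\CCC/C(=C\c3ccc(OC)c(OC)c3)C2=O)cc1` gives 7800 nM in this assay. How the core of compound 3 differs from the core of compound 1 is not broken down here.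

Compound 4 `COc1ccc(/C=C2\CCC/C(=C\c3ccc(OC)c(OC)c3)C2=O)c(OC)c1` is still to be measured in this assay. It differs from compound 3 by methoxy in place of hydrogen on an aromatic carbon, the same kind of change as before, though the place differs: earlier the new group stood ortho to a hydroxy group and meta to a large group, here it stands ortho to a large group and meta to a methoxy group. Resting on compound 2 with 11600 nM against compound 1, the step is expected to be a 1.3-fold lower number from compound 3 to compound 4 (0.11 log units; within the scatter). For compound 4 the estimate in this assay is 6000 nM, between 2500 nM and 15000 nM.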

Compound 4, half-maximal inhibitory concentration: 15600 nM
Compound 4: the middle estimate sits 2.6-fold (0.41 log units) below what was measured, and the stated range ends below it.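

In this assay, methoxy in place of hydrogen on an aromatic carbon brings a 2.0-fold higher number from compound 3 to compound 4 (0.30 log units; within the scatter), a step that lies within the scatter when taken alone. Set beside the earlier step, the same change does not carry over unchanged from one core to the other: the same change on two cores in this assay, an at least 1.7-fold lower number (0.23 log units; that floor lies within the scatter) from compound 1 to compound 2 and a 2.0-fold higher number (0.30 log units; within the scatter) from compound 3 to compound 4, at least 3.4-fold (0.53 log units) apart, beyond the scatter of two such steps. This does not show what sets the two steps apart, as both the core and the place of the new group differ between them, and the earlier step is known only as a floor.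

The compounds shown carry only hydroxy and methoxy groups on their aromatic rings. They leave open whether an amine, a carboxylic acid or a longer alkoxy chain in these places would follow either step.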